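This account rests on a few compounds, and the source may have more. Where it says the series, first, only, none or still open, it means among the compounds named here.

Compound 1 `CCC(C)Sc1nc(N)nc2c1ncn2[C@@H]1O[C@H](CO)[C@@H](O)[C@H]1O` carries a (sec-butyl)sulfanyl group on the shared core. In an assay on isolated protein for binding affinity to Equilibrative nucleoside transporter 1 (Homo sapiens) (on this read-out higher numbers stand for weaker inhibition and lower numbers for stronger inhibition), compound 1 gives 63100 nM, the lower of the two numbers in hand, while compound 2 `CCCn1cnc2c(SC(C)C)nc(N)nc21` gives 145000 nM in this assay, a gap beyond the usual scatter. Compound 3 `Nc1nc(SCCc2ccccc2)c2ncn([C@@H]3O[C@H](CO)[C@@H](O)[C@H]3O)c2n1` differs from compound 1 in one place: phenethyl in place of sec-butyl on a sulfur. For the measured compounds named here, no measured pair shows a step of this kind, so the expectation rests on the change alone. For the step of a 4.2-fold lower number from compound 1 to compound 3 (0.62 log units; beyond the scatter) a modest gain in inhibition is expected, beyond the scatter. Compound 3 is estimated at 15000 nM in this assay, within 3000 nM to 80000 nM.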

Compound 3, half-maximal inhibitory concentration: 16200 nM
Estimate against measurement, compound 3: 1.1-fold (0.03 log units) below, within the range that was stated.
By their numbers in this assay, from the lowest: compound 3; then compound 1; then compound 2.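

In this assay, replacing sec-butyl with phenethyl on a sulfur gives a 3.9-fold lower number from compound 1 to compound 3 (0.59 log units; beyond the scatter) at this place, the only measured step here among the compounds shown. It shows that this substituent on sulfur affects the read-out and that a larger group carrying a six-membered aromatic ring is compatible with a modest gain in inhibition. Nothing at hand accounts for the step. The compounds shown leave open whether the aromatic ring or the longer chain matters more, which benzyl or straight-chain hexyl on the sulfur could help separate. They also leave open how an amine or a carboxylic acid on the phenethyl ring would read.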